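Compound 3 to compound 4: butyl replaced by cyclopropyl

The source may hold more compounds than are shown below. What is called first, only, known or untested is meant among the compounds shown, and "the series" means these compounds.

Of the compounds shown here, three have been measured in a physicochemical assay for lipophilicity, read by HPLC, at pH 7.5; on this read-out higher numbers stand for higher lipophilicity and lower numbers for lower lipophilicity. Compound 1 `CCOc1ccccc1-c1ccc(-c2nc3cnccc3c(C[C@H](C)C(=O)O)c2C#N)cc1` gives 2.2, compound 2 `CCOc1ccccc1-c1ccc(-c2nc3cnccc3c(N[C@H](CC)C(=O)NS(=O)(=O)C3CC3)c2C#N)cc1` gives 2.3, and compound 3 `CCCCC(Nc1c(C#N)c(-c2ccc(-c3ccccc3OCC)cc2)nc2cnccc12)C(N)=O` gives 3.6. Compound 3 is thus the highest of the three, and both gaps to it lie beyond the scatter.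

Compound 4 `CCOc1ccccc1-c1ccc(-c2nc3cnccc3c(NC(C(N)=O)C3CC3)c2C#N)cc1` keeps the structure of compound 3 except for one change: cyclopropyl in place of butyl on a saturated chain carbon bound to a carbonyl carbon and a nitrogen on an aromatic ring. Cyclopropyl stands in place of butyl on a saturated chain carbon bound to a carbonyl carbon and a nitrogen on an aromatic ring.

Among the compounds with values here, two measured steps bear on this change, both large: a number 1.40 log units higher from compound 1 to compound 3 (beyond the scatter) and a number 1.30 log units higher from compound 2 to compound 3 (beyond the scatter). Within the data shown here, each exchanges a much wider part of the molecule, so neither isolates butyl against cyclopropyl, and no measured pair makes this exact swap. They show only how far this read-out has moved in the series. The change here is confined to one group, and the entering group is the smaller by the heavy-atom count, so a moderate fall is expected, smaller than a number 1.30 log units higher from compound 2 to compound 3 (beyond the scatter). The expected step is a number 0.50 log units lower from compound 3 to compound 4 (beyond the scatter). For compound 4 the estimate is 3.1, with an expected range from 2.7 to 3.5.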

Compound 4, distribution coefficient: 3
Estimate against measurement, compound 4: 0.10 log units above; the range from low to high includes it.
By their numbers in this assay, from the lowest: compounds 1 and 2 (each within the scatter of the next); then compound 4; then compound 3.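

In this assay, within the data shown here, the saturated chain carbon bound to a carbonyl carbon and a nitrogen on an aromatic ring proves responsive on its own: cyclopropyl in place of butyl gives a number 0.60 log units lower from compound 3 to compound 4 (beyond the scatter) in a change confined to one group, whereas the earlier steps each exchanged a wider part of the molecule. Compound 4 also keeps its order against the two lowest compounds, with a number 0.70 log units higher from compound 2 to compound 4 (beyond the scatter) and a number 0.80 log units higher from compound 1 to compound 4 (beyond the scatter) in the wider exchanges, so the order seen with compound 3 survives the loss of butyl. No measured information is available to explain the size of these steps.

This single swap changes the heavy-atom count and introduces a ring together, so the two cannot be separated; isopropyl, cyclobutyl or a longer chain at the same carbon would show how the read-out tracks each of them. From the compounds shown here alone, it also remains open whether butyl and cyclopropyl differ by a similar amount when the neighbouring amide gives way to a carboxylic acid or an amine.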